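This account rests on a few compounds, and the source may have more. Where it says the series, first, only, none or still open, it means among the compounds named here.

Of the compounds shown here, two of this small series have been tested so far, both built on the same aminotriazole acetic acid core. Compound 1 `Nc1nc(CC(=O)O)n[nH]1` carries the free acid on that core, and in a functional assay on the whole organism (strain albino) for inhibition, with Rattus norvegicus as the target, read by paw edema, with stated times of 30 min and 1 h, at a dose of 5 mg/kg by the oral route (a lower number here means less inhibition, a higher number more inhibition at the dose given (going by the name of the read-out)), compound 1 gives 22.3%. Compound 2 `CCOC(=O)Cc1nc(N)n(C(=O)c2ccccc2)n1` is the ethyl ester of the same acid, with a benzoyl group on a ring nitrogen, and in this assay compound 2 gives 31.6%. Compound 2 has the larger of the two numbers, but the gap to compound 1 lies within the usual scatter, so on these two measurements the pair cannot be told apart.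

Compound 3 `CCOC(=O)Cc1nc(N)n(C(=O)c2ccc(Cl)cc2)n1` has not been measured in this assay. It differs from compound 2 in one place: chloro in place of hydrogen on an aromatic carbon. Cut one bond further out, the same difference reads phenyl to 4-chlorophenyl.

Among the measured compounds shown here, with no comparable step among the measured compounds, the size of this change is an open question. The step from compound 2 to compound 3 is expected to be small, most likely within the scatter a number 3.4 percentage points higher from compound 2 to compound 3 (within the scatter). Compound 3 is therefore estimated at 35%, in a range from 20% to 50%.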

Compound 3, a percentage reported as inhibition, in the whole organism at one dose (the size of the read-out at that dose, not a potency): 34.2%
For compound 3 the middle estimate is 0.8 percentage points above the measured one; the measured number falls inside the stated range.
By their numbers in this assay, from the lowest: compounds 1, 2 and 3 (each within the scatter of the next, the first and the last beyond it).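

In this assay, putting chloro in place of hydrogen on an aromatic carbon, para to a large group, gives a number 2.6 percentage points higher from compound 2 to compound 3 (within the scatter). Among the compounds shown here, this is the first change that can be read in one place, and it shows that turning the phenyl of the benzoyl group into 4-chlorophenyl leaves compound 2 and compound 3 indistinguishable at this single oral dose. The step therefore gives no sign that this position matters for the read-out, though one small substituent is a narrow test, and nothing measured here speaks to what the chlorine does in the animal.

From the compounds shown here alone, whether a different group at the same place, such as an amine, a methoxy group or a carboxylic acid, would move the number beyond the scatter stays open. Going by these compounds, the separate shares of the ethyl ester and the benzoyl group also stay open: compound 1 and compound 2 differ in more than one place, so their pair cannot be read as a single change.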